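Carboxylic Acid to Hydroxypyrrolidine Amide: Expected Stability

This account rests on a few compounds, and the source may have more. Where it says the series, first, only, none or still open, it means among the compounds named here.

Measured compounds:
compound 1 `CS(=O)(=O)c1ccc(-c2cnc(N)c(-c3ccc(N)nc3)n2)cc1`: > 90%
compound 2 `Nc1ncc(-c2ccc(C(=O)O)cc2)nc1-c1ccc(C(F)(F)F)cc1`: > 90%
compound 3 `Nc1ccc(-c2cnc(N)c(-c3ccc(N)nc3)n2)cn1`: > 90%

All readings come from an ADME assay on microsomes from liver (Mus musculus) for metabolic stability, read by LC-MS, using NADPH, with a stated time of 30 min, tested at 0.1 uM, in the presence of a further agent that is not named here; a higher number here means that more of the compound is left, a lower number that less of the compound is left. In this assay compound 1 gives > 90%, which is a limit of the assay and not a number. Compound 3 gives > 90%, again a limit. Compound 2 gives > 90%, also a limit. Among the compounds with values here, all three readings therefore rest at the limit of > 90% in this assay, at which 3 of the 3 values shown sit, and compound 2 stands level with the other two at the top of what the assay reports; no measured compound sits anywhere else. Within the data shown here, no pair of measured compounds differs in only one place, so no measured step ties a value to a single structural change.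

Compound 4 `Nc1ncc(-c2ccc(C(=O)N3CC[C@H](O)C3)cc2)nc1-c1ccc(C(F)(F)F)cc1` has not yet been measured. It differs from compound 2 in one place: 3-hydroxypyrrolidin-1-yl in place of hydroxy on a carbonyl carbon. The numbers shown give no instance of any change moving a compound off the limit, and nothing here points to a loss on this change either. The expected step is a number at least 5 percentage points lower from compound 2 to compound 4 (that floor lies within the scatter), none beyond the scatter. Compound 4 is accordingly estimated at 85%, within a range from 60% to 100%.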

Compound 4, percent of the compound remaining: > 90%
Compound 4: only a limit was reported; the forecaster's own chance of this, stated with the estimate: 50%; at least 5 percentage points between middle value and limit.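

Within the data shown here, the readings of compound 2 and compound 4 are both limits and not numbers, so no step between these two compounds can be read, and the values stay together: the limit of > 90% in this assay, at which 4 of the 4 values shown sit. The compounds shown leave open whether any structural change moves a compound off this limit, and how much of each compound actually remains.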